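The source may report more compounds than this note shows. Statements on the series, on what has been measured and on what is new or still open speak of the compounds shown alone.

Among the compounds with values here, in a functional assay on the whole organism (blood, strain ICR) with Mus musculus as the target, in the glucose tolerance test, with a stated time of 30 min (on this read-out higher numbers stand for an effect only at larger amounts of compound and lower numbers for an effect already at smaller amounts), compound 1 `O=S1(=O)Cc2nc(-c3cc(F)c(Cl)cc3F)nc(N3CCC(CCO)CC3)c2C1` gives 1 mg/kg, the lowest of the two numbers measured so far. Within the data shown here, compound 2 `NC(=O)CN1CCN(c2nc(-c3cc(F)c(Cl)cc3F)nc3c2CS(=O)(=O)C3)CC1` in this assay gives 3 mg/kg, and the single measured step between them, a 3.0-fold higher number from compound 1 to compound 2 (0.48 log units; beyond the scatter), comes from putting 4-(carbamoylmethyl)piperazin-1-yl in place of 4-(2-hydroxyethyl)piperidin-1-yl on an aromatic carbon. Compound 3 `CN(C)C(=O)C1CCN(c2nc(-c3cc(F)c(Cl)cc3F)nc3c2CS(=O)(=O)C3)CC1` keeps the six-membered non-aromatic ring with one nitrogen of compound 1 and changes only its side chain: dimethylcarbamoyl in place of 2-hydroxyethyl on a saturated ring carbon. This is not the same exchange as the one measured, yet it bears on it, since in both cases the 2-hydroxyethyl piece is lost and a carbamoyl-type group enters. That one measured step, modest and beyond the scatter, points towards a higher number. Compound 3 is therefore expected to lie somewhat above compound 1 in this assay, with an estimated step of a 2.0-fold higher number from compound 1 to compound 3 (0.30 log units; within the scatter), of roughly the size seen from compound 1 to compound 2 or a little smaller. The estimate for compound 3 is 2 mg/kg, within a range from 1 mg/kg to 6 mg/kg.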

Compound 3, minimum effective dose: 1 mg/kg
For compound 3 the middle estimate is 2.0-fold (0.30 log units) above the measured one, and the stated range covers the measured number.
By their numbers in this assay, from the lowest: compounds 1 and 3 (each within the scatter of the next); then compound 2.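

In this assay, the exchange at this saturated ring carbon gives no change at the digits printed from compound 1 to compound 3 (within the scatter), so this position accepts dimethylcarbamoyl in place of 2-hydroxyethyl with no step beyond the scatter, even though the entering group has no hydrogen-bond donor and the leaving group has one. Losing 2-hydroxyethyl and gaining a carbamoyl-type group is therefore not enough on its own to produce a step like a 3.0-fold higher number from compound 1 to compound 2 (0.48 log units; beyond the scatter), which also replaced the six-membered ring with one nitrogen by a piperazine. No supporting measurement is available to explain why the number holds at this position.

The compounds shown leave open whether the same ring carbon would hold its number with a primary carboxamide, which keeps the amide hydrogens, with a carboxylic acid, or with a basic amine such as dimethylaminomethyl. They also leave open how far the side chain can grow, since a longer chain such as 3-hydroxypropyl or a larger amide such as morpholine-4-carbonyl would test the limits of this position.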